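Aryl change on the sulfonyl of compound 3

The source may hold more compounds than are shown below. What is called first, only, known or untested is meant among the compounds shown, and "the series" means these compounds.

In a functional assay on DU-145 cells (Homo sapiens) for antiproliferative activity, read by propidium iodide staining, with a stated time of 96 h (a higher number here means a weaker inhibitor, a lower number a stronger inhibitor), compound 1 (`CC(O)(COc1cccc(OC(F)(F)F)c1)C(=O)Nc1ccc(S(F)(F)(F)(F)F)cc1`) gives 18400 nM and compound 2 (`CC(O)(CS(=O)(=O)c1ccc(S(F)(F)(F)(F)F)cc1)C(=O)Nc1cccc(S(F)(F)(F)(F)F)c1`) gives 17400 nM. Compound 3 (`CC(O)(CS(=O)(=O)c1ccc(F)cc1)C(=O)Nc1cccc(S(F)(F)(F)(F)F)c1`) gives 48800 nM, the highest number of the three and thus the weakest inhibition in the set.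

Compound 4 (`CC(O)(CS(=O)(=O)c1ccccc1C(F)(F)F)C(=O)Nc1cccc(S(F)(F)(F)(F)F)c1`) carries 2-(trifluoromethyl)phenyl in place of 4-fluorophenyl on a sulfonyl sulfur.

Among the measured compounds shown here, only one measured step touches the aryl group on the sulfonyl sulfur: a 2.8-fold higher number from compound 2 to compound 3 (0.45 log units; beyond the scatter). This step is modest but beyond the scatter, and in it a single fluorine atom replaces a larger group. For the measured compounds named here, compound 1 has no sulfonyl sulfur and offers no comparable step. Going by the values given here, no measured compound carries 2-(trifluoromethyl)phenyl, so the evidence is thin. Compound 4 also has the larger aryl group of its pair, so by analogy with a 2.8-fold higher number from compound 2 to compound 3 (0.45 log units; beyond the scatter) a move toward a lower number in this assay is expected, though a smaller one that may not clear the scatter. The expected change is a 1.7-fold lower number from compound 3 to compound 4 (0.24 log units; within the scatter). For compound 4 the estimate is 28000 nM, with an expected range of 12000 nM to 60000 nM.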

Compound 4, half-maximal inhibitory concentration: 27300 nM
Beside the measured number, compound 4's estimate is 1.0-fold (0.01 log units) above it, and the stated range covers the measured number.
By their numbers in this assay, from the lowest: compounds 2, 1, 4 and 3 (each within the scatter of the next, the first and the last beyond it).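

The step of a 1.8-fold lower number from compound 3 to compound 4 (0.25 log units; within the scatter) stays within the scatter in this assay, so 2-(trifluoromethyl)phenyl in place of 4-fluorophenyl on a sulfonyl sulfur does not separate the two compounds, even though the entering group has 10 heavy atoms against 7 for the group that leaves. Among the compounds shown here, until now, the only step read at this aryl group was a 2.8-fold higher number from compound 2 to compound 3 (0.45 log units; beyond the scatter) and it lay beyond the scatter, so this pair adds the first aryl change on the sulfonyl sulfur that leaves the number within the scatter, and the position does not respond to every change made there. No measured property of these compounds is available to account for either step.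

With both the substituent and its place on the ring differing between compound 3 and compound 4, the two contributions to this step cannot be told apart. Going by these compounds, it also remains open how the number would respond to an amine or a carboxylic acid on this aryl ring, or to a longer chain between the ring and the sulfonyl sulfur.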